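This account rests on a few compounds, and the source may have more. Where it says the series, first, only, none or still open, it means among the compounds named here.

Measured compounds:
compound 1 `CS(=O)(=O)NC1CCC(CN2CCN(c3cc(=O)c4cc(C(F)(F)F)cc([N+](=O)[O-])c4s3)CC2)CC1`: 105%
compound 2 `O=C(OC1CCC(CN2CCN(c3cc(=O)c4cc(C(F)(F)F)cc([N+](=O)[O-])c4s3)CC2)CC1)c1cccs1`: 2.2%
compound 3 `O=C(OC1CCC(CN2CCN(c3cc(=O)c4cc(C(F)(F)F)cc([N+](=O)[O-])c4s3)CC2)CC1)c1ccc(C(F)(F)F)cc1`: 5.2%

In an ADME assay on cells (Hepatocyte, Homo sapiens) for metabolic stability, with a stated time of 30 min (on this read-out lower numbers stand for a less stable compound and higher numbers for a more stable compound), compound 2 stands lowest of the three numbers; compound 3 is nearest, with a number 3 percentage points higher from compound 2 to compound 3 (within the scatter), and compound 1 is furthest, with a number 102.8 percentage points lower from compound 1 to compound 2 (beyond the scatter) read in the other direction. Compound 4 `O=c1cc(N2CCN(CC3CCC(NS(=O)(=O)c4ccccc4)CC3)CC2)sc2c([N+](=O)[O-])cc(C(F)(F)F)cc12` is not yet measured in this assay. It differs from compound 2 in one place: (phenylsulfonyl)amino in place of ((thiophen-2-yl)carbonyl)oxy on a saturated ring carbon.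

Among the compounds with values here, of the two measured steps, the one from compound 1 to compound 2 bears most on this change, since it also exchanges the methanesulfonamido group on the same saturated ring carbon for ((thiophen-2-yl)carbonyl)oxy and gives a large drop, a number 102.8 percentage points lower from compound 1 to compound 2 (beyond the scatter). The step from compound 2 to compound 3 exchanges only the group on the carbonyl carbon and stays within the scatter, a number 3 percentage points higher from compound 2 to compound 3 (within the scatter). Compound 4 reinstates a sulfonyl-bearing nitrogen on that ring carbon, so a large rise is expected, a number 72.8 percentage points higher from compound 2 to compound 4 (beyond the scatter). Whether the phenyl group in place of methyl on the sulfonyl lets compound 4 reach the number of compound 1 cannot be read from these three compounds; compound 4 is estimated at 75%, within 40% to 105%.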

Compound 4, percent of the compound remaining: 90.8%
Compound 4: middle estimate off by 15.8 percentage points, on the low side; low and high end bracket the measured number.
By their numbers in this assay, from the lowest: compounds 2 and 3 (each within the scatter of the next); then compound 4; then compound 1.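

In this assay, (phenylsulfonyl)amino in place of ((thiophen-2-yl)carbonyl)oxy on the saturated ring carbon gives a number 88.6 percentage points higher from compound 2 to compound 4 (beyond the scatter), so a high read-out at this position is not confined to the methanesulfonamido group of compound 1. The group on the sulfonyl sulfur still registers: phenyl in place of methyl gives a number 14.2 percentage points lower from compound 1 to compound 4 (beyond the scatter), a modest step beside the large one on leaving the ester. No measurement at hand gives a cause for either step.

Open, as far as these compounds go, is how an amide on that ring carbon, carrying the same (thiophen-2-yl)carbonyl group on nitrogen, would read, and with it whether the sulfonyl or the nitrogen link goes with the higher numbers. Also open, from the compounds shown here alone, is where an ethyl chain or a pyridine ring on the sulfonyl sulfur would fall relative to methyl and phenyl.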